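The compounds below may be only part of what the source reports. "The series", "measured", "known", "first", "only" and "open" are said of these compounds alone.

In a functional assay on HeLa cells (Homo sapiens) for antiproliferative activity, read by sulforhodamine B assay, with a stated time of 48 h (a higher number here means a weaker inhibitor of growth, a lower number a stronger inhibitor of growth), compound 3 (`CCCCc1cn(CCCN2C(=O)COc3ccccc32)nn1`) gives 1020 nM as the lowest of three numbers, with compound 2 (`COc1ccc(-c2cn(CCCN3C(=O)COc4ccccc43)nn2)cc1`) at 4900 nM and compound 1 (`O=C1COc2ccccc2N1CCCn1cc(-c2ccccc2)nn1`) at 9000 nM above it. The change to compound 4 (`CCCc1cn(CCCN2C(=O)COc3ccccc32)nn1`) is hydrogen in place of methyl on a saturated chain carbon, three bonds along the chain from an aromatic carbon here, butyl to propyl. The measured steps bear on this only indirectly: butyl replacing phenyl gave an 8.8-fold lower number from compound 1 to compound 3 (0.95 log units; beyond the scatter) and butyl replacing 4-methoxyphenyl gave a 4.8-fold lower number from compound 2 to compound 3 (0.68 log units; beyond the scatter) as modest steps, while methoxy gave a 1.8-fold lower number from compound 1 to compound 2 (0.26 log units; within the scatter) within the scatter. Among the compounds with values here, no measured pair varies chain length alone. Butyl to propyl is a smaller edit than either swap to butyl, so a slightly higher number in this assay is expected, with a 1.5-fold higher number from compound 3 to compound 4 (0.17 log units; within the scatter) as the estimated step and probably nothing beyond the scatter. For compound 4 the estimate is 1500 nM with an expected range from 700 nM to 4000 nM in this series.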

Compound 4, concentration for 50% growth inhibition: 23200 nM
For compound 4 the middle estimate is 15-fold (1.19 log units) below the measured one, outside the stated range (above it).
By their numbers in this assay, from the lowest: compound 3; then compounds 2 and 1 (each within the scatter of the next); then compound 4.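

In this assay this position proves far more sensitive than the earlier swaps showed: butyl to propyl, the loss of a single methyl, gives a 23-fold higher number from compound 3 to compound 4 (1.36 log units; beyond the scatter), the largest step in the series. A lower number for an alkyl chain than for an aryl group does not hold in general, since propyl gives a 4.7-fold higher number from compound 2 to compound 4 (0.68 log units; beyond the scatter) and a 2.6-fold higher number from compound 1 to compound 4 (0.41 log units; beyond the scatter), so compound 4 goes against the pattern set by compound 3. Nothing available accounts for this loss. Open, as far as these compounds go, is how a longer chain such as pentyl reads here, and whether an amine on the chain keeps the low number of compound 3.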